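This account rests on a few compounds, and the source may have more. Where it says the series, first, only, none or still open, it means among the compounds named here.

The series shares one core, on which only the urea-linked aryl group varies. Compound 1 `Cc1ccc(NC(=O)Nc2nnc(Sc3ncnc4scc(-c5ccncc5)c34)s2)cc1Cl` gives 23200 nM in a functional assay on HUVEC cells (Homo sapiens) for antiproliferative activity, read by MTT assay, with a stated time of 48 h; a lower number here means a stronger inhibitor, a higher number a weaker inhibitor. Compound 2 `COc1ccc(NC(=O)Nc2nnc(Sc3ncnc4scc(-c5ccncc5)c34)s2)cc1` gives 16900 nM in this assay, and compound 3 `Cc1ccc(NC(=O)Nc2nnc(Sc3ncnc4scc(-c5ccncc5)c34)s2)cc1` gives 19300 nM in this assay. Among these three numbers compound 3 stands second highest; its nearest neighbour is compound 2 and its furthest is compound 1, and both gaps are within the scatter, so no order among the three can be claimed. The step now followed leads to compound 4 `O=C(Nc1ccc(F)cc1)Nc1nnc(Sc2ncnc3scc(-c4ccncc4)c23)s1`, not yet measured: fluoro in place of methyl on an aromatic carbon, on a six-membered aromatic ring of carbon only, para to a large group. The measured steps that bear on it all alter this same aryl substituent: a 1.4-fold lower number from compound 1 to compound 2 (0.14 log units; within the scatter), a 1.2-fold lower number from compound 1 to compound 3 (0.08 log units; within the scatter) and a 1.1-fold higher number from compound 2 to compound 3 (0.06 log units; within the scatter). None of them moves the number beyond the scatter, so no step beyond the scatter is expected for the exchange of methyl for fluoro either, in neither direction. The expected step is a 1.0-fold lower number from compound 3 to compound 4 (0.01 log units; within the scatter). Compound 4 is accordingly estimated at 19000 nM, with a range from 9000 nM to 40000 nM.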

Compound 4, half-maximal inhibitory concentration: 28300 nM
Compound 4: middle estimate off by 1.5-fold (0.17 log units), on the low side; measured number inside the range.
By their numbers in this assay, from the lowest: compounds 2, 3, 1 and 4 (each within the scatter of the next).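

With fluoro in the place para to a large group, the comparison now covers a halogen as well as methyl and methoxy there: in this assay the exchange gives a 1.5-fold higher number from compound 3 to compound 4 (0.17 log units; within the scatter), and the exchange for methoxy gives a 1.7-fold higher number from compound 2 to compound 4 (0.22 log units; within the scatter). Among these compounds, the replacement of the whole aryl group of compound 1 gives a 1.2-fold higher number from compound 1 to compound 4 (0.09 log units; within the scatter), so the flat picture from the earlier compounds now extends to a halogen at this position, and even the largest step so far stays inside the scatter. No measurement bears on why the numbers stay so close.

As far as these compounds go, whether any group at this place can move the number beyond the scatter stays open, for example an amine, a carboxylic acid or a longer chain. From the compounds shown here alone, the shared core is also constant throughout, so the effect of a change there on this assay is unknown.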